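This account rests on a few compounds, and the source may have more. Where it says the series, first, only, none or still open, it means among the compounds named here.

Measured so far in a functional assay on SK-BR-3 cells (Homo sapiens) for antiproliferative activity; on this read-out lower numbers stand for stronger inhibition and higher numbers for weaker inhibition:
compound 1 `COc1ccc(Oc2ccc3cc(NC(=O)c4ccc(O)c(CC=C(C)C)c4)c(=O)oc3c2C)cc1`, 42700 nM;
compound 2 `CC(C)=CCc1cc(C(=O)Nc2cc3ccc(Oc4ccc(C(C)(C)C)cc4)c(C)c3oc2=O)ccc1O`, 68300 nM;
compound 3 `COc1cc(Cc2ccc3cc(NC(=O)c4ccc(O)c(CC=C(C)C)c4)c(=O)oc3c2C)ccc1O`, 10700 nM.

Compound 3 gives the lowest of the three numbers, set apart by a 4.0-fold lower number from compound 1 to compound 3 (0.60 log units; beyond the scatter) and by a 6.4-fold lower number from compound 2 to compound 3 (0.81 log units; beyond the scatter), both beyond the scatter. Compound 4 `CC(C)=CCc1cc(C(=O)Nc2cc3ccc(Cc4ccc(O)cc4)c(C)c3oc2=O)ccc1O` differs from compound 3 by hydrogen in place of methoxy on an aromatic carbon. For the measured compounds named here, no measured step removes a methoxy from this ring. The nearest comparison is a 1.6-fold higher number from compound 1 to compound 2 (0.20 log units; within the scatter), where tert-butyl took the place of methoxy on the phenoxy group without a change beyond the scatter. The two larger steps exchanged the whole side group, not a single methoxy. On this basis no step beyond the scatter is expected in this assay, a 1.1-fold higher number from compound 3 to compound 4 (0.05 log units; within the scatter). Compound 4 is estimated at 12000 nM, within 4000 nM to 36000 nM.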

Compound 4, half-maximal inhibitory concentration: 21500 nM
Estimate against measurement, compound 4: 1.8-fold (0.25 log units) below; the measured number falls inside the stated range.
By their numbers in this assay, from the lowest: compounds 3, 4, 1 and 2 (each within the scatter of the next, the first and the last beyond it).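

In this assay, hydrogen in place of methoxy, ortho to a hydroxy group, stays within the scatter (a 2.0-fold higher number from compound 3 to compound 4 (0.30 log units; within the scatter)), so this methoxy is not shown to be needed at this position. The 4-hydroxybenzyl group remains separated from 4-(tert-butyl)phenoxy (a 3.2-fold lower number from compound 2 to compound 4 (0.50 log units; beyond the scatter)), but not from 4-methoxyphenoxy (a 2.0-fold lower number from compound 1 to compound 4 (0.30 log units; within the scatter)). No measurement offered here accounts for these steps.

Open, on these data alone, is whether ethoxy, an amine or a carboxylic acid on this same carbon would give a step beyond the scatter.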